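Pyrrolidine amide in place of benzyl ester

The source may report more compounds than this note shows. Statements on the series, on what has been measured and on what is new or still open speak of the compounds shown alone.

Measured so far:
compound 1, `O=C(O)CC[C@H](NC(=O)c1cc2ccccc2[nH]1)C(=O)N(C1CCCCC1)C1CCCCC1`: 3400 nM
compound 2, `CCCCCN(CCCCC)C(=O)C(CCC(=O)OCc1ccccc1)NC(=O)Nc1ccc(Cl)cc1`: 16000 nM

Of the compounds shown here, two have been measured in an assay for inhibition of Cholecystokinin receptor type A (Cavia porcellus); a higher number here means a weaker inhibitor, a lower number a stronger inhibitor. Compound 1 gives 3400 nM and compound 2 gives 16000 nM. Compound 2 stands with the higher of the two numbers, and the gap to compound 1 lies beyond the scatter. Going by the values given here, the two compounds differ in several places at once, so no single step between them can be read.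

Compound 3, `CCCCCN(CCCCC)C(=O)C(CCC(=O)N1CCCC1)NC(=O)Nc1ccc(Cl)cc1`, is the next compound. It differs from compound 2 in one place: pyrrolidin-1-yl in place of benzyloxy on a carbonyl carbon. Among the compounds with values here, no measured pair shows what this kind of exchange does in this assay, and compound 1, which carries a free acid at the corresponding position, differs from compound 2 too widely to serve as a guide. The step expected here, a 1.3-fold lower number from compound 2 to compound 3 (0.12 log units; within the scatter), is therefore modest and is not expected to exceed the usual scatter in either direction. Compound 3 is expected to give about 12000 nM, with a range from 2500 nM to 50000 nM.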

Compound 3, half-maximal inhibitory concentration: 250 nM
Compound 3: middle estimate off by 48-fold (1.68 log units), on the high side, outside the stated range (below it).
By their numbers in this assay, from the lowest: compound 3; then compound 1; then compound 2.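

In this assay, exchanging benzyloxy for pyrrolidin-1-yl on a carbonyl carbon gives a 64-fold lower number from compound 2 to compound 3 (1.81 log units; beyond the scatter), with the rest of the molecule unchanged. This single-place step shows that the group on this carbonyl carbon has a strong bearing on the number, which the earlier pair, differing in several places at once, could not show. The exchange turns an ester into an amide and replaces a six-membered aromatic ring of carbon only with a five-membered non-aromatic ring, and this one pair cannot separate those changes. No measurement at hand bears on why the number falls so far.

The compounds shown leave open whether the step belongs to pyrrolidin-1-yl itself or would also come with a piperidin-1-yl or dimethylamino group on the same carbonyl carbon. Compound 1 carries a carboxylic acid at the corresponding position but differs from the other two compounds in several places, so what a free acid would do on the shared frame of compound 2 and compound 3 cannot be read.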